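Fluorophenyl for Methoxyphenyl on the Shared Ketone

The compounds below may be only part of what the source reports. "The series", "measured", "known", "first", "only" and "open" are said of these compounds alone.

Compound 1 `COc1cccc(C(=O)c2ccc3c(ccn3S(=O)(=O)c3cccc(/C=C/C(=O)NO)c3)c2)c1` gives 3530 nM in an assay on isolated protein for inhibition of histone deacetylase 8 (Homo sapiens) (on this read-out higher numbers stand for weaker inhibition and lower numbers for stronger inhibition), the highest number of the two measured. Compound 2 `Cc1ccc(C(=O)c2ccc3c(ccn3Cc3ccc(C(=O)NO)cc3)c2)cc1` gives 1490 nM in this assay; the two compounds differ in several places at once, so their values are only compared, not traced to one change. Compound 3 `O=C(/C=C/c1cccc(S(=O)(=O)n2ccc3cc(C(=O)c4ccc(F)cc4)ccc32)c1)NO` is not yet measured. It carries 4-fluorophenyl in place of 3-methoxyphenyl on a carbonyl carbon. Among the compounds with values here, no measured pair shows this change alone, so the expected step is a 1.2-fold lower number from compound 1 to compound 3 (0.07 log units; within the scatter), not beyond the scatter in either direction. Compound 3 is thus estimated at 3000 nM, with a range from 1200 nM to 8000 nM.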

Compound 3, half-maximal inhibitory concentration: 2750 nM
Compound 3: middle estimate off by 1.1-fold (0.04 log units), on the high side; low and high end bracket the measured number.
By their numbers in this assay, from the lowest: compounds 2, 3 and 1 (each within the scatter of the next, the first and the last beyond it).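

In this assay, within the data shown here, the change of 3-methoxyphenyl to 4-fluorophenyl on a carbonyl carbon reads as a 1.3-fold lower number from compound 1 to compound 3 (0.11 log units; within the scatter) and is the first step confined to one place. This position therefore tolerates this exchange of aryl groups, including the loss of the methoxy oxygen, without a change beyond the scatter. No supporting data on the compounds bear on this result.

Open, from the compounds shown here alone, is whether an aminomethyl or carboxylic acid group on the aryl ring at this carbonyl would shift the number beyond the scatter. Going by these compounds, the same exchange on the core of compound 2 also remains open.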